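This account rests on a few compounds, and the source may have more. Where it says the series, first, only, none or still open, it means among the compounds named here.

Compound 1 (`COc1ccc(C2C(O)C(=O)N2c2cc(OC)c(OC)c(OC)c2)cc1`): 4 nM
Compound 2 (`CCSc1ccc(C2C(Oc3ccccc3)C(=O)N2c2cc(OC)c(OC)c(OC)c2)cc1`): 210 nM

In a functional assay on MCF7 cells (Homo sapiens) for inhibition, read by resazurin assay, with a stated time of 72 h (a lower number here means a stronger inhibitor, a higher number a weaker inhibitor), compound 2 has the higher number of the two (210 nM), and the gap to compound 1 (4 nM) lies beyond the scatter. Compound 3 (`COc1ccc(C2C(Oc3ccccc3)C(=O)N2c2cc(OC)c(OC)c(OC)c2)cc1`) differs from compound 2 in one place, with methoxy in place of ethylsulfanyl on an aromatic carbon. Going by the values given here, no measured step isolates this change. A moderate fall in the number, beyond the scatter, is still expected since compound 1 with its 4-methoxyphenyl gives 4 nM and compound 3 carries that same group. The expected change is (a 3.0-fold lower number from compound 2 to compound 3 (0.48 log units; beyond the scatter)). For compound 3 the estimated value is 70 nM (range 15 nM to 300 nM).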

Compound 3, half-maximal inhibitory concentration: 23 nM
For compound 3 the middle estimate is 3.0-fold (0.48 log units) above the measured one; the measured number falls inside the stated range.
By their numbers in this assay, from the lowest: compound 1; then compound 3; then compound 2.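

In this assay, methoxy in place of ethylsulfanyl on the aromatic carbon gives a 9.1-fold lower number from compound 2 to compound 3 (0.96 log units; beyond the scatter) with the rest of the molecule unchanged, so this position responds to the group it carries. With the 4-methoxyphenyl held fixed, phenyl in place of hydrogen on the oxygen gives a 5.8-fold higher number from compound 1 to compound 3 (0.76 log units; beyond the scatter) and leaves the compound still in the low range of these numbers. Nothing at hand offers a reason for either step.

As far as these compounds go, how an amine or chlorine would read at the aromatic position stays open. So does the effect of a methyl or a longer chain on the oxygen.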